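A Methyl Group Added to a Halogen Series

The source may hold more compounds than are shown below. What is called first, only, known or untested is meant among the compounds shown, and "the series" means these compounds.

- compound 1 `O=C(NS(=O)(=O)c1ccc(F)cc1)c1cccnc1Cl` gives 12500 nM
- compound 2 `O=C(NS(=O)(=O)c1ccc(Br)cc1)c1cccnc1Cl` gives 11400 nM
- compound 3 `O=C(NS(=O)(=O)c1ccc(Cl)cc1)c1cccnc1Cl` gives 10200 nM

All three values come from a functional assay on MCF7 cells (Homo sapiens) for antiproliferative activity, read by MTT assay, with a stated time of 48 h; a higher number here means a weaker inhibitor, a lower number a stronger inhibitor. Compound 2 stands level with the other two, since the step of a 1.1-fold lower number from compound 1 to compound 2 (0.04 log units; within the scatter) and the step of a 1.1-fold lower number from compound 2 to compound 3 (0.05 log units; within the scatter) cannot be told apart from ordinary repeat variation. The same holds for the step of a 1.2-fold lower number from compound 1 to compound 3 (0.09 log units; within the scatter).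

Compound 4 `Cc1ccc(C(=O)NS(=O)(=O)c2ccc(Br)cc2)c(Cl)n1` keeps the bromo group of compound 2 and has one change: methyl in place of hydrogen on an aromatic carbon, next to the ring nitrogen (methyl in place of hydrogen on an aromatic carbon). For the measured compounds named here, none of the measured steps adds a methyl. Each swaps one halogen for another, and they offer only indirect guidance. They show that this series has so far stayed level in this assay, but they do not test the new position. A step beyond the scatter is therefore not expected, and no direction is favoured. The estimated change is small, a 1.1-fold lower number from compound 2 to compound 4 (0.06 log units; within the scatter). Compound 4 is expected near 10000 nM, with an estimated range of 4000 nM to 25000 nM.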

Compound 4, half-maximal inhibitory concentration: 1970 nM
Beside the measured number, compound 4's estimate is 5.1-fold (0.71 log units) above it, and the stated range ends above it.
By their numbers in this assay, from the lowest: compound 4; then compounds 3, 2 and 1 (each within the scatter of the next).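

In this assay, adding one methyl on the aromatic carbon next to the ring nitrogen gives a 5.8-fold lower number from compound 2 to compound 4 (0.76 log units; beyond the scatter) and so moves the number by more than ordinary repeat variation. The earlier compounds only exchanged one halogen for another, and those exchanges stayed within the scatter, so this carbon is the one place among the compounds shown where a single change clearly alters antiproliferative potency. Nothing measured here gives a reason for the step.

On these data alone, it remains open whether a larger chain such as ethyl or propyl, or a different group such as an amine or methoxy, would lower the number further at this carbon or raise it again. It is also unknown whether the methyl would give a similar step with fluoro or chloro in place of the bromo group.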